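Removing the pyrazolylamino group from a kinase inhibitor core

A few compounds are considered here, and "the series" means these few. Any claim that something is new, unique, unknown or untested is made for them only; others in the source may bear on it.

Of the compounds shown here, two have been measured in an assay on isolated protein for inhibition of Leucine-rich repeat serine/threonine-protein kinase 2 (Homo sapiens), read by TR-FRET and LanthaScreen, with stated times of 50 min and 30 min, in the presence of a further agent that is not named here; on this read-out lower numbers stand for stronger inhibition and higher numbers for weaker inhibition. Compound 1 `Cc1cn(C)nc1Nc1cc2c(c(N)n1)c(C#N)c(N1CCC[C@H]1C)n2C` gives 2110 nM. Going by the values given here, compound 2 `C[C@@H]1CCCN1c1c(C#N)c2c(N)nc(Nc3ccn(C)n3)cc2n1C` gives 234 nM, the lowest of the two numbers, and the only measured step is a 9.0-fold lower number from compound 1 to compound 2 (0.96 log units; beyond the scatter). Compound 3 `C[C@@H]1CCCN1c1c(C#N)c2c(N)nccc2n1C` has not yet been measured; it differs from compound 2 by hydrogen in place of (1-methyl-1H-pyrazol-3-yl)amino on an aromatic carbon.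

Among the compounds with values here, the single measured step concerns a methyl on the pyrazole and not the loss of the whole (1-methyl-1H-pyrazol-3-yl)amino group, so no step in hand speaks directly to the change from compound 2 to compound 3. Taking away a group of this size from the shared core is a far larger change than the one measured, and in the absence of any guide the expectation is that inhibition weakens considerably. Compound 3 is therefore expected to give 6000 nM in this assay, with a range from 1500 nM to 30000 nM. This corresponds to an estimated step of a 26-fold higher number from compound 2 to compound 3 (1.41 log units; beyond the scatter), well beyond the scatter and in the direction of weaker inhibition.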

Compound 3, half-maximal inhibitory concentration: 34 nM
Compound 3: the middle estimate sits 180-fold (2.25 log units) above what was measured; the whole stated range lies above it.
By their numbers in this assay, from the lowest: compound 3; then compound 2; then compound 1.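

In this assay, the (1-methyl-1H-pyrazol-3-yl)amino group on this aromatic carbon next to the ring nitrogen turns out not to be needed for inhibition: exchanging it for a bare hydrogen gives a 6.9-fold lower number from compound 2 to compound 3 (0.84 log units; beyond the scatter) and so strengthens inhibition rather than weakening it. The exchange of the (1,4-dimethyl-1H-pyrazol-3-yl)amino group for hydrogen gives an even larger change, a 62-fold lower number from compound 1 to compound 3 (1.79 log units; beyond the scatter), so across these three compounds the number falls at each stage as the group at this position is trimmed, from the dimethylpyrazole to the methylpyrazole to nothing at all, and no compound shown goes against this order. Nothing available alongside these numbers explains this trend.

What the compounds leave open is whether hydrogen is the best choice at this carbon, since a small group such as methyl, methoxy or chlorine could move the number in either direction. From the compounds shown here alone, it is also open whether the same order would hold with a different group in place of the other substituents on the shared core.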